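Series notes: chain variation two bonds from the aromatic nitrogen

A few compounds are considered here, and "the series" means these few. Any claim that something is new, unique, unknown or untested is made for them only; others in the source may bear on it.

Measured so far:
- compound 1, `CCSCCCn1c(N2CCN(C)CC2)nc2ccccc21`: 530 nM
- compound 2, `CC(C)CCn1c(N2CCN(C)CC2)nc2ccccc21`: 1400 nM

Both compounds share the core and differ only in the group on the saturated chain carbon two bonds along the chain from the aromatic nitrogen. In a functional assay on ileum for inhibition of histamine H1 receptor (Cavia porcellus) (a lower number here means a stronger inhibitor, a higher number a weaker inhibitor), compound 1 gives 530 nM, and compound 2 gives 1400 nM. The step of a 2.6-fold higher number from compound 1 to compound 2 (0.42 log units; beyond the scatter) is the only one measured; compound 2 therefore stands with the highest number of the two, compound 1 the nearest.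

Compound 3, `CN1CCN(c2nc3ccccc3n2CCO)CC1`, is not yet measured. It differs from compound 2 by hydroxy in place of isopropyl on a saturated chain carbon, two bonds along the chain from an aromatic nitrogen. For the measured compounds named here, no measured step exchanges an alkyl group at this position for a hydroxy group, so the one measured step bears on it only loosely: it shows that the number at this position moves with the identity of the chain group by a modest amount. On that basis a change of similar size, with the number of compound 3 expected to move further upward from compound 2, is anticipated as a 2.1-fold higher number from compound 2 to compound 3 (0.33 log units; beyond the scatter), though the direction is uncertain. Compound 3 is thus estimated at 3000 nM in this assay, within a range of 800 nM to 12000 nM.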

Compound 3, half-maximal inhibitory concentration: 410 nM
Compound 3: middle estimate off by 7.3-fold (0.86 log units), on the high side; measured number outside the range, below it.
By their numbers in this assay, from the lowest: compounds 3 and 1 (each within the scatter of the next); then compound 2.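

Working from this assay, the exchange of isopropyl for hydroxy on the saturated chain carbon, two bonds along the chain from an aromatic nitrogen, gives a 3.4-fold lower number from compound 2 to compound 3 (0.53 log units; beyond the scatter) and runs opposite to the earlier step, so compound 2 now stands apart from both other compounds. Hydroxy in place of (ethylsulfanyl)methyl gives a 1.3-fold lower number from compound 1 to compound 3 (0.11 log units; within the scatter), which places compound 1 and compound 3 level despite the very different groups at this position. Among these three compounds, isopropyl is the only group made of carbon alone and the only one with a number beyond the scatter from the others, although this rests on compound 2 alone, and no measurement on hand explains the difference.

Open, from the compounds shown here alone, is whether an amine or a methoxy group on this carbon would fall with compound 1 and compound 3 or with compound 2, which would test whether the all-carbon reading holds. Also open, going by these compounds, is whether a longer chain ending in hydroxy stays near the 410 nM of compound 3 in this assay or moves toward the higher number of compound 2.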